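The source may hold more compounds than are shown below. What is called first, only, known or untested is meant among the compounds shown, and "the series" means these compounds.

Working notes on the series in a functional assay on A549 cells (Homo sapiens) for inhibition; on this read-out higher numbers stand for weaker inhibition and lower numbers for stronger inhibition. Compound 1 `COc1ccc(/C=C/c2ccc3ccccc3c2)cc1` is reported only as a limit, > 5000 nM. Compound 2 `COc1cccc(/C=C\c2ccc3ccccc3c2)c1` gives 1920 nM, the higher of the two actual numbers. Compound 3 `COc1cc(/C=C\c2ccc3ccccc3c2)ccc1F` gives 450 nM. Next comes compound 4 `FC(F)(F)Oc1cccc(/C=C\c2ccc3ccccc3c2)c1`, with this change: trifluoromethyl in place of methyl on an oxygen on an aromatic ring. Among the measured compounds shown here, the only measured step nearby is a different change, fluoro in place of hydrogen on an aromatic carbon, which gave a 4.3-fold lower number from compound 2 to compound 3 (0.63 log units; beyond the scatter), so it is a loose guide at best. In this assay a slight shift toward a lower number is expected, not beyond the scatter: a 1.5-fold lower number from compound 2 to compound 4 (0.17 log units; within the scatter). For compound 4 the estimate is 1300 nM, with an expected range of 400 nM to 4500 nM.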

Compound 4, half-maximal inhibitory concentration: 3500 nM
Compound 4: middle estimate off by 2.7-fold (0.43 log units), on the low side, within the range that was stated.
By their numbers in this assay, from the lowest: compound 3; then compounds 2 and 4 (each within the scatter of the next). At a limit, above all of these: compound 1.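

In this assay, going from methoxy to trifluoromethoxy gives a 1.8-fold higher number from compound 2 to compound 4 (0.26 log units; within the scatter), so the replacement of methyl by trifluoromethyl on this oxygen does not separate the two compounds. This place on the ring therefore accepts a group of four heavy atoms in place of one without a change that can be read, unlike the ring fluoro step, a 4.3-fold lower number from compound 2 to compound 3 (0.63 log units; beyond the scatter). No measurement shown accounts for this outcome.

Open, from the compounds shown here alone, is how a longer chain such as ethoxy or a free hydroxyl would read here. Also open, going by these compounds, is whether trifluoromethoxy behaves the same alongside the fluoro group of compound 3.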